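Saturated ring carbon substituent: cyclohexyl against phenyl

A few compounds are considered here, and "the series" means these few. Any claim that something is new, unique, unknown or untested is made for them only; others in the source may bear on it.

The set shares the core of compound 1 `Cc1ccc(S(=O)(=O)N2CC=C(Br)CC2)cc1`; compound 2 `Cc1ccc(S(=O)(=O)N2CCC(Br)=CC2CC(C)C)cc1` and compound 3 `Cc1ccc(S(=O)(=O)N2CCC(Br)=CC2C2CCCCC2)cc1` carry isobutyl and cyclohexyl on a saturated ring carbon. In a functional assay on WiDr cells (Homo sapiens) for antiproliferative activity, read by sulforhodamine B assay, with a stated time of 48 h (on this read-out higher numbers stand for weaker inhibition of growth and lower numbers for stronger inhibition of growth), compound 1 gives > 100000 nM, which is a limit of the assay and not a number. Compound 2 gives 16000 nM in this assay. Compound 3 gives 18000 nM in this assay and stands level with compound 2, since a 1.1-fold higher number from compound 2 to compound 3 (0.05 log units; within the scatter). The two steps from the unsubstituted parent, an at least 6.2-fold lower number from compound 1 to compound 2 (0.79 log units; beyond the scatter) and an at least 5.5-fold lower number from compound 1 to compound 3 (0.74 log units; beyond the scatter), are the only ones beyond the scatter, and both rest on a limit (the limit of > 100000 nM in this assay, at which 1 of the 3 values shown sits).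

Compound 4 `Cc1ccc(S(=O)(=O)N2CCC(Br)=CC2c2ccccc2)cc1` differs from compound 3 by phenyl in place of cyclohexyl on a saturated ring carbon. Among the measured compounds shown here, the step that bears on it is the swap between two large groups in the same place, a 1.1-fold higher number from compound 2 to compound 3 (0.05 log units; within the scatter), which stayed within the scatter; no measured step tests an aromatic ring there. A step of no size beyond the scatter is therefore expected in this assay, with wide uncertainty. Compound 4 is estimated at 15000 nM, between 4000 nM and 60000 nM, meaning an expected 1.2-fold lower number from compound 3 to compound 4 (0.08 log units; within the scatter).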

Compound 4, concentration for 50% growth inhibition: 29000 nM
Beside the measured number, compound 4's estimate is 1.9-fold (0.29 log units) below it, within the range that was stated.
By their numbers in this assay, from the lowest: compounds 2, 3 and 4 (each within the scatter of the next). At a limit, above all of these: compound 1.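

In this assay, phenyl on this saturated ring carbon, next to the ring nitrogen, is the one aromatic ring among the compounds shown, and it stays level with both non-aromatic groups: a 1.6-fold higher number from compound 3 to compound 4 (0.21 log units; within the scatter), and a 1.8-fold higher number from compound 2 to compound 4 (0.26 log units; within the scatter). Isobutyl, cyclohexyl and phenyl are therefore not told apart here, and an aromatic ring in place of a non-aromatic one makes no change beyond the scatter. Phenyl also shows an at least 3.4-fold lower number from compound 1 to compound 4 (0.53 log units; beyond the scatter), and this step rests on the value of compound 1, which is a limit: the limit of > 100000 nM in this assay, at which 1 of the 4 values shown sits.

On these data alone, whether an amine, a carboxylic acid or a methyl group at this carbon would move the number beyond the scatter stays open. Also open, as far as these compounds go, is whether chloro in place of the bromo group would change the number with these groups present.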